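The source may report more compounds than this note shows. Statements on the series, on what has been measured and on what is new or still open speak of the compounds shown alone.

Measured so far:
compound 1 `Nc1nc(F)nc2c1ncn2[C@@H]1O[C@H](CO)C=C1F` — > 100000 nM
compound 2 `Nc1nc(Cl)c2ncn([C@@H]3O[C@H](CO)C=C3F)c2n1` — 30200 nM; > 100000 nM (2 entries)

In an ADME assay on CCRF-CEM cells (Homo sapiens) for cytotoxicity (on this read-out lower numbers stand for stronger inhibition and higher numbers for weaker inhibition), compound 1 gives only > 100000 nM, which is a limit of the assay and not a number. Compound 2 in this assay is recorded as 30200 nM; > 100000 nM (2 entries), where the several entries do not agree with one another; the several entries of compound 2 in this assay, 30200 nM; > 100000 nM (2 entries) and the limit of > 100000 nM in this assay, at which 1 of the 2 values shown sits, show how wide the spread of these readings is. Among the compounds with values here, no step between measured compounds is available, so compound 1 stands on a limit alone, with nothing to rank it against.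

Compound 3 `Nc1nc(F)nc2c1ncn2[C@H]1O[C@H](CO)C=C1F` differs from compound 1 in that (the two compounds have the same atoms and bonds and differ only in configuration as drawn: 1 of 2 stereo elements differ; a stereocentre at a saturated ring carbon is drawn R in compound 1 and S in compound 3). Nothing measured in the series bears on such an inversion, so no step beyond the usual scatter is expected in this assay in either direction. Compound 3 is therefore expected to sit at 100000 nM, with a range from 30000 nM to 300000 nM. This corresponds to an expected step of a number no higher from compound 1 to compound 3 (the limit leaves the size open).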

Compound 3, half-maximal inhibitory concentration: 28300 nM
Beside the measured number, compound 3's estimate is 3.5-fold (0.55 log units) above it; measured number below the stated range.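

In this assay, within the data shown here, the change from R to S at this saturated ring carbon comes with an at least 3.5-fold lower number from compound 1 to compound 3 (0.54 log units; beyond the scatter), the first step readable, and configuration is the only change that can account for it: the fact that compounds 1 and 3 differ only in the configuration as drawn. Going by these compounds, compound 1 stands at a limit of the assay and not at a number, so the true size of the step remains unknown: the limit of > 100000 nM in this assay, at which 1 of the 3 values shown sits. Entries for one compound can disagree widely in this series, so the single reading for compound 3 carries limited weight: the several entries of compound 2 in this assay, 30200 nM; > 100000 nM (2 entries).

On these data alone, whether this inversion would give a similar step in a compound bearing a carboxylic acid in place of the hydroxymethyl group remains open. The second stereo element is drawn the same in compound 1 and compound 3, so the effect of changing it is also unknown.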